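The compounds below may be only part of what the source reports. "The series", "measured", "known", "first", "only" and "open" are said of these compounds alone.

In a functional assay on MCF7 cells (Homo sapiens) for cytotoxicity, read by MTT assay, with a stated time of 48 h (on this read-out lower numbers stand for stronger inhibition and higher numbers for weaker inhibition), compound 1 `COc1ccc(-c2nnc(SCCn3c([N+](=O)[O-])cnc3C)o2)cc1` gives 10600 nM, compound 2 `Cc1ncc([N+](=O)[O-])n1CCSc1nnc(-c2ccccc2F)o1` gives 20500 nM and compound 3 `Cc1ncc([N+](=O)[O-])n1CCSc1nnc(-c2ccc(F)cc2)o1` gives 8100 nM. Compound 3 therefore cannot be separated from compound 1, given a 1.3-fold lower number from compound 1 to compound 3 (0.12 log units; within the scatter). It does stand apart from compound 2, given a 2.5-fold lower number from compound 2 to compound 3 (0.40 log units; beyond the scatter), although that step is modest. The third measured step, a 1.9-fold higher number from compound 1 to compound 2 (0.29 log units; within the scatter), stays within the scatter.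

Compound 4 `Cc1ccc(-c2nnc(SCCn3c([N+](=O)[O-])cnc3C)o2)c(O)c1` differs from compound 3 by 2-hydroxy-4-methylphenyl in place of 4-fluorophenyl on an aromatic carbon of a five-membered aromatic ring with 2 nitrogen and 1 oxygen: 2-hydroxy-4-methylphenyl in place of 4-fluorophenyl on an aromatic carbon. Among the compounds with values here, no measured compound carries this group, so the three steps bear on the change only indirectly. They suggest that exchanges at this place have moved the numbers little, the largest being the modest step to compound 3 from compound 2. In this assay, the expected change is a 1.2-fold higher number from compound 3 to compound 4 (0.09 log units; within the scatter), which means no expected shift beyond the scatter. Compound 4 is estimated at 10000 nM, with an expected range from 3500 nM to 28000 nM.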

Compound 4, half-maximal inhibitory concentration: 23500 nM
Estimate against measurement, compound 4: 2.4-fold (0.37 log units) below, within the range that was stated.
By their numbers in this assay, from the lowest: compounds 3, 1, 2 and 4 (each within the scatter of the next, the first and the last beyond it).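

In this assay, the step from 4-fluorophenyl to 2-hydroxy-4-methylphenyl shows that this place can respond to an exchange beyond the scatter, though only modestly (a 2.9-fold higher number from compound 3 to compound 4 (0.46 log units; beyond the scatter)), and the same holds against 4-methoxyphenyl (a 2.2-fold higher number from compound 1 to compound 4 (0.35 log units; beyond the scatter)). Compound 4 cannot be separated from the 2-fluorophenyl compound (a 1.1-fold higher number from compound 2 to compound 4 (0.06 log units; within the scatter)), so two different groups, both named with a substituent at the 2 position, give numbers that lie beyond the scatter from compound 3. Compound 2 goes against any simple reading of this, as it cannot be separated from compound 1, whereas compound 4 can.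

The change brings in hydroxy and methyl together, so the compounds shown do not say which of the two goes with the step, nor how an aminophenyl or a carboxylic acid would read at this place. No measurement at hand gives a reason for these steps.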